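Trifluoromethyl for Chloro on a Second Core

The source may report more compounds than this note shows. Statements on the series, on what has been measured and on what is new or still open speak of the compounds shown alone.

Compound 1, `CC(=O)c1ccc2c(c1)nc(-c1ccc(Cl)cc1)n2C1CCCCC1`: in an ADME assay on MT4 cells (Homo sapiens) for cytotoxicity, read by MTT assay, with a stated time of 96 h (a lower number here means that less compound is tolerated, a higher number that more compound is tolerated), compound 1 gives 58000 nM.
Compound 2, `CC(=O)c1ccc2c(c1)nc(-c1ccc(C(F)(F)F)cc1)n2C1CCCCC1`: in this assay compound 2 gives 41000 nM.
Compound 3, `C/C(=N\NC(N)=S)c1ccc2c(c1)nc(-c1ccc(Cl)cc1)n2C1CCCCC1`: in this assay compound 3 gives 17000 nM.

Compounds 1 and 2 share a core and differ in one place: trifluoromethyl in place of chloro on an aromatic carbon. That change made a 1.4-fold lower number from compound 1 to compound 2 (0.15 log units; within the scatter). Compound 3 differs from compound 1 in another place: a group of 7 heavy atoms (3 carbon, 3 nitrogen, 1 sulfur; no ring) in place of a group of 3 heavy atoms (2 carbon, 1 oxygen; no ring), on an aromatic carbon. That change made a 3.4-fold lower number from compound 1 to compound 3 (0.53 log units; beyond the scatter), so compound 3 has the lowest number of the three measured compounds, meaning less of it is tolerated by the cells.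

Compound 4, `C/C(=N\NC(N)=S)c1ccc2c(c1)nc(-c1ccc(C(F)(F)F)cc1)n2C1CCCCC1`, has not yet been measured. It differs from compound 3 as follows: trifluoromethyl in place of chloro on an aromatic carbon. Among the compounds with values here, this is the same change as the one from compound 1 to compound 2, now made on the core of compound 3; the surroundings of the place are described in the same words for both pairs. The change has been seen only once before, so the expectation rests on a single example. Compound 4 is expected to show a step of similar small size, a 1.4-fold lower number from compound 3 to compound 4 (0.15 log units; within the scatter), because a 1.4-fold lower number from compound 1 to compound 2 (0.15 log units; within the scatter) lay within the scatter. Compound 4 is therefore estimated at 12000 nM, with the number expected to fall between 6000 nM and 30000 nM.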

Compound 4, half-maximal cytotoxic concentration: 30000 nM
Estimate against measurement, compound 4: 2.5-fold (0.40 log units) below; the measured number falls inside the stated range.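

In this assay, within the data shown here, putting trifluoromethyl in place of chloro on the core of compound 3 gives a 1.8-fold higher number from compound 3 to compound 4 (0.25 log units; within the scatter), and the two cores show no difference in how they take this change: the same change on two cores in this assay, a 1.4-fold lower number (0.15 log units; within the scatter) from compound 1 to compound 2 and a 1.8-fold higher number (0.25 log units; within the scatter) from compound 3 to compound 4, 2.5-fold (0.40 log units) apart, within the scatter of two such steps The other change, made on the core of compound 2, gives a 1.4-fold lower number from compound 2 to compound 4 (0.14 log units; within the scatter), and this step also cannot be told apart from its earlier counterpart: the same change on two cores in this assay, a 3.4-fold lower number (0.53 log units; beyond the scatter) from compound 1 to compound 3 and a 1.4-fold lower number (0.14 log units; within the scatter) from compound 2 to compound 4, 2.5-fold (0.40 log units) apart, within the scatter of two such steps The two trifluoromethyl steps point in opposite directions on paper, but both lie within the scatter, so this is no real reversal; the result shows only that the swap carried from one core to the other here without a visible difference, not that it would do so on every core or in any other kind of test, since it rests on just two pairs of compounds.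

The compounds shown leave open how a nitrile, a methoxy group or a carboxylic acid would behave in place of chloro at this place on the ring. They also leave open whether the swap would stay this small on a third core.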